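A few compounds are considered here, and "the series" means these few. Any claim that something is new, unique, unknown or untested is made for them only; others in the source may bear on it.

In a functional assay on NCI-H460 cells (Homo sapiens) for cytotoxicity, read by MTT assay (on this read-out lower numbers stand for stronger inhibition and higher numbers for weaker inhibition), compound 1 `COc1ccc(/C=C/C(=O)c2sc(Nc3ccc(Cl)c(Cl)c3)nc2C)cc1` gives > 25000 nM, which is a limit of the assay rather than a number. Compound 3 `COc1ccc(/C=C/C(=O)c2sc(Nc3ccc(Cl)cc3)nc2C)cc1` likewise gives > 25000 nM in this assay, again only a limit. Compound 2 `Cc1ccccc1Nc1nc(C)c(C(=O)/C=C/c2ccccc2Cl)s1` also stands at > 25000 nM, a limit as well. The one single-point step among these three, a step that the two limits leave unreadable from compound 1 to compound 3, cannot be read, because of the limit of > 25000 nM in this assay, at which 3 of the 3 values shown sit. For the measured compounds named here, compound 1 therefore stands at the limit with the other two, and no step has a readable size or direction.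

Going by the values given here, compound 4 `Cc1nc(Nc2ccc(Cl)c(Cl)c2)sc1C(=O)/C=C/c1ccccc1` differs from compound 1 by a change that no measured pair covers: hydrogen in place of methoxy on an aromatic carbon. Among the compounds with values here, the only measured step, from compound 1 to compound 3, bears on it just in showing that a change on the distant aromatic ring left the value at the limit; it gives no size to carry over. With three limits and no readable step, the step from compound 1 to compound 4 is expected to be none beyond the scatter, a step that the limit leaves unreadable from compound 1 to compound 4. Compound 4 is accordingly estimated at 30000 nM, within a range from 8000 nM to 100000 nM, with the most likely outcome that this assay again reports only a limit.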

Compound 4, half-maximal inhibitory concentration: 22700 nM
The estimate for compound 4 lay 1.3-fold (0.12 log units) above the measured number; the measured number falls inside the stated range.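

In this assay, for the compounds shown here, the change from 4-methoxyphenyl to phenyl reads as an at least 1.1-fold lower number from compound 1 to compound 4 (0.04 log units; that floor lies within the scatter), the first step that can be read at all, and it can be read only as a floor. Compound 1 stays a limit, > 25000 nM. From the compounds shown here alone, what is new is that with hydrogen on this aromatic carbon, para to a large group, compound 4 gives an actual number, 22700 nM, so the methoxy group is not needed for a number to appear, though how large the step really is stays unknown. The remaining values sit at one limit: the limit of > 25000 nM in this assay, at which 3 of the 4 values shown sit.

Going by these compounds, whether a hydroxyl group, an amine or a longer chain such as ethoxy at this place would also give a number, and how that number would stand against compound 4, remains open. Also open, on these data alone, is whether the same change of methoxy to hydrogen on compound 3 would give a number too, as this change is seen in a single pair only.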